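Adding one carbon to the sulfonyl chain

The compounds below may be only part of what the source reports. "The series", "measured", "known", "first", "only" and "open" are said of these compounds alone.

Compound 1 (`CS(=O)(=O)N1CCC2(CC1)OOC1(CCCC1)OO2`) and compound 2 (`CCS(=O)(=O)N1CCC2(CC1)OOC1(CCCC1)OO2`) share one core and differ only in the chain on the sulfonyl group. In a functional assay on Huh-7 cells (Homo sapiens) for cytotoxicity, read by MTT assay, with a stated time of 72 h (on this read-out lower numbers stand for higher toxicity in this test and higher numbers for lower toxicity in this test), compound 1 gives > 100 ug/mL as a limit of the assay. Compound 2 gives > 100 ug/mL as a limit too, so it has no exact number. The change to compound 3 (`CCCS(=O)(=O)N1CCC2(CC1)OOC1(CCCC1)OO2`) is methyl in place of hydrogen on a saturated chain carbon, two bonds along the chain from a sulfonyl sulfur and turns ethylsulfonyl into propylsulfonyl. Going by the values given here, the one measured step of a similar kind is a step that the two limits leave unreadable from compound 1 to compound 2 and offers no size to carry over. The record so far is the limit of > 100 ug/mL in this assay, at which 2 of the 2 values shown sit, and contains no exact number. No step beyond the usual scatter is therefore expected in this assay and no direction can be named. The expected step is a step that the limit leaves unreadable from compound 2 to compound 3 for this small change. For compound 3 the estimated value is 150 ug/mL with an expected range from 60 ug/mL to 400 ug/mL in this test.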

Compound 3, half-maximal cytotoxic concentration: > 100 ug/mL
Compound 3 ended at the assay's limit; the forecaster's own chance of this, stated with the estimate: 85%; the middle value does not contradict the limit.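

No new step can be read among compound 1, compound 2 and compound 3, because all of them stop at a limit of the assay and give no exact number: the limit of > 100 ug/mL in this assay, at which 3 of the 3 values shown sit. The compounds shown leave open how toxic each one really is in this assay and whether the length of the sulfonyl chain matters there.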